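Swapping 4-methylcyclohexyl for 4,4-difluorocyclohexyl on a carbonyl carbon

The source may report more compounds than this note shows. Statements on the series, on what has been measured and on what is new or still open speak of the compounds shown alone.

Measured compounds in an ADME assay on MT4 cells (Homo sapiens) for cytotoxicity, with a stated time of 5 days (a higher number here means that more compound is tolerated, a lower number that less compound is tolerated), each value a limit:
Compound 1 `CC(C)N(c1cc(C#CC(C)(C)C)sc1C(=O)O)C(=O)[C@H]1CC[C@H](C)CC1`: > 20000 nM
Compound 2 `CC(C)(C)C#Cc1cc(N(C(=O)[C@H]2CC[C@H](C)CC2)[C@H]2CC[C@H](OC3COC3)CC2)c(C(=O)O)s1`: > 20000 nM
Compound 3 `CC(C)(C)C#Cc1cc(N(C(=O)[C@H]2CC[C@H](C)CC2)[C@H]2CC[C@H](OC3CCOC3)CC2)c(C(=O)O)s1`: > 20000 nM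

Compound 1 stands only at a limit, with no number read for it. The measured set offers (the limit of > 20000 nM in this assay, at which 3 of the 3 values shown sit). Compound 4 `CC(C)N(C(=O)C1CCC(F)(F)CC1)c1cc(C#CC(C)(C)C)sc1C(=O)O` has not yet been measured, and it differs from compound 1 as follows: 4,4-difluorocyclohexyl in place of 4-methylcyclohexyl on a carbonyl carbon. The nearest measured evidence is a step that the two limits leave unreadable from compound 1 to compound 2 and a step that the two limits leave unreadable from compound 1 to compound 3. For the measured compounds named here, both changes fall on an amide-type nitrogen, and no measured step changes the group on the carbonyl carbon. No step beyond the scatter is therefore expected in this assay. The estimated change is a number no higher from compound 1 to compound 4 (the limit leaves the size open). For compound 4 the expected value is 20000 nM, with an estimated range of 12000 nM to 40000 nM.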

Compound 4, half-maximal cytotoxic concentration: > 20000 nM
Compound 4: only a limit was reported; the forecaster's own chance of this, stated with the estimate: 85%; the middle value lies on the limit itself.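

In this assay compound 4 gives > 20000 nM, which is a limit, and its step from compound 1 cannot be read. The compounds shown leave open whether 4,4-difluorocyclohexyl in place of 4-methylcyclohexyl changes the tolerated concentration at all.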